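Methyl Position on the Benzoate Ester of a Monoterpene Core

The source may report more compounds than this note shows. Statements on the series, on what has been measured and on what is new or still open speak of the compounds shown alone.

Measured compounds:
- compound 1 `CC1=CC[C@H](C(C)C)c2cc(C)c(OC(=O)c3cccc(C)c3)cc21`: "not active" (no number reported)
- compound 2 `Cc1cc2c(C(C)C)ccc(C)c2cc1OC(=O)c1ccc([N+](=O)[O-])cc1`: 100%

In a functional assay on SK-LU-1 cells (Homo sapiens) for antiproliferative activity, read by sulforhodamine B assay, with a stated time of 48 h, tested at 50 uM (on this read-out lower numbers stand for less inhibition and higher numbers for more inhibition at the one concentration tested (going by the name of the read-out)), compound 1 gives "not active" (no number reported), so no single number stands for it; the result is reported as not active rather than as a figure. In this assay, within the data shown here, compound 2 gives 100%, but compound 2 has a different core and a different substituent on its ester, and no step between compound 1 and compound 2 is counted here, so the two values show only that compound 1 is reported as not active while compound 2 has the higher inhibition in this assay.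

Compound 3 `CC1=CC[C@H](C(C)C)c2cc(C)c(OC(=O)c3ccc(C)cc3)cc21` differs from compound 1 in one place: 4-methylphenyl in place of 3-methylphenyl on a carbonyl carbon. The two share every atom and every other bond. With only the methyl moved on the ester ring, and compound 1 reported as not active, the expected step in this assay is none beyond the scatter, with no clear direction. Compound 3 is therefore expected to sit at 12%, within 0% to 40%.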

Compound 3, a percentage reported as inhibition, at one concentration (the size of the read-out at that concentration, not a potency): 85.4%
For compound 3 the middle estimate is 73.4 percentage points below the measured one; the measured number lies above the stated range.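

In this assay, among these compounds, compound 1 gives "not active" (no number reported) and compound 3 gives 85.4% but without a number for compound 1, no step between them can be read. Nothing measured here accounts for this result. The compounds shown leave open how large the gap between compound 1 and compound 3 really is.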